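Chloro for fluoro on the phenyl ring of compound 2

The source may report more compounds than this note shows. Statements on the series, on what has been measured and on what is new or still open speak of the compounds shown alone.

Compound 1 `O=c1[nH]cc(S(=O)(=O)Nc2ccc(-c3cn(-c4ccccc4)nn3)cc2)c(=O)[nH]1` is the unsubstituted parent; in a functional assay on SGC-7901 cells (Homo sapiens) for antiproliferative activity, read by MTT assay, with a stated time of 24 h (on this read-out lower numbers stand for stronger inhibition and higher numbers for weaker inhibition), compound 1 gives 18800 nM. Compound 2 `O=c1[nH]cc(S(=O)(=O)Nc2ccc(-c3cn(-c4cccc(F)c4)nn3)cc2)c(=O)[nH]1` carries fluoro in place of hydrogen on an aromatic carbon; in this assay compound 2 reaches only the limit > 20000 nM, which is the limit of > 20000 nM in this assay, at which 1 of the 2 values shown sits. The step of an at least 1.0-fold higher number from compound 1 to compound 2 (0.02 log units; that floor lies within the scatter) therefore stands only as a floor and says nothing about its true size. Compound 3 `O=c1[nH]cc(S(=O)(=O)Nc2ccc(-c3cn(-c4cccc(Cl)c4)nn3)cc2)c(=O)[nH]1` differs from compound 2 by chloro in place of fluoro on an aromatic carbon, that is 3-fluorophenyl to 3-chlorophenyl. Going by the values given here, the only measured step that bears on this position is the one from compound 1 to compound 2, and it gives no more than that floor; no step from fluoro to chloro exists. Compound 3 is expected to show a step that the limit leaves unreadable from compound 2 to compound 3 in this assay, with no direction beyond the scatter and quite possibly again only a limit. Compound 3 is estimated at 25000 nM, in the range 10000 nM to 70000 nM.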

Compound 3, half-maximal inhibitory concentration: 2460 nM
Estimate against measurement, compound 3: 10-fold (1.01 log units) above; measured number outside the range, below it.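

In this assay, going by these compounds alone, 3-chlorophenyl gives the first change at this position whose size can be read as a number, with a 7.6-fold lower number from compound 1 to compound 3 (0.88 log units; beyond the scatter). The position therefore does not treat every halogen alike: chloro and fluoro are separated by an at least 8.1-fold lower number from compound 2 to compound 3 (0.91 log units; beyond the scatter). That step stands only as a floor, as compound 2 sits at a limit of the assay rather than at a number: the limit of > 20000 nM in this assay, at which 1 of the 3 values shown sits.

Open, from the compounds shown here alone, is whether bromo or trifluoromethyl in the same place, on the same shared core, would lower the number further than chloro does, or whether the trend stops at chloro. Also open, going by these compounds, is whether a group of a different kind there, such as an amine or a carboxylic acid, would keep any of the step seen with chloro.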